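The compounds below may be only part of what the source reports. "The series", "measured", "known", "first", "only" and "open" are said of these compounds alone.

Working notes on the hydroxamate series in an assay on Sf9 cells for inhibition of histone deacetylase 11 (Homo sapiens), read by fluorescence, tested at 0.5 uM; on this read-out higher numbers stand for more inhibition at the one concentration tested (going by the name of the read-out) and lower numbers for less inhibition.

Compound 1 `O=C(/C=C/c1cn([C@@H]2C[C@@H](C(=O)O)N(Cc3ccccc3)C2)nn1)NO` gives 12% in this assay. Compound 2 `O=C(/C=C/c1cn([C@H]2C[C@@H](C(=O)O)N(CCCc3ccccc3)C2)nn1)NO`, which carries the longer phenylpropyl chain on the ring nitrogen of the shared core, gives 29% in this assay. For compound 3 `O=C(NO)c1cccc(-c2cn([C@@H]3C[C@@H](C(=O)O)N(CCCc4ccccc4)C3)nn2)c1` the read-out is only a limit, < 10% in this assay; it sits at the limit of < 10% in this assay, at which 1 of the 3 values shown sits, so compound 3 stands at the floor of the values seen here, with no number of its own.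

Compound 4 `O=C(/C=C/c1cn([C@@H]2C[C@@H](C(=O)O)N(CCCc3ccccc3)C2)nn1)NO` has not yet been measured in this assay. It differs from compound 3 by 2-(hydroxycarbamoyl)ethenyl in place of 3-(hydroxycarbamoyl)phenyl on an aromatic carbon. The change puts the 2-(hydroxycarbamoyl)ethenyl group on the five-membered aromatic ring with 3 nitrogen, the same arrangement found in compound 1 and compound 2, both of which return numbers rather than a limit in this assay.

Taking compound 2, which shares the phenylpropyl chain and the 2-(hydroxycarbamoyl)ethenyl group with compound 4, as the nearest measured point, the step from compound 3 to compound 4 is expected to lift the read-out, a number at least 12 percentage points higher from compound 3 to compound 4 (beyond the scatter), out of the limit and beyond the scatter. Compound 4 is expected to give about 22% in this assay, with a range from 10% to 38%.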

Compound 4, a percentage reported as inhibition, at one concentration (the size of the read-out at that concentration, not a potency): < 10%
Compound 4: no number, only a limit; the forecaster's own chance of this, stated with the estimate: 25%; middle value at least 12 percentage points away from the limit.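

In this assay compound 4 gives < 10%, which is a limit and not a number, and with compound 3 also at a limit the exchange of 3-(hydroxycarbamoyl)phenyl for 2-(hydroxycarbamoyl)ethenyl at this position cannot be read: the limit of < 10% in this assay, at which 2 of the 4 values shown sit.

The 2-(hydroxycarbamoyl)ethenyl group therefore does not by itself secure a measurable read-out, and the one step clearly beyond the scatter is at the stereocentre on the saturated ring carbon, a number at least 19 percentage points lower from compound 2 to compound 4 (beyond the scatter), which can be assigned to the drawn configuration alone: the fact that compounds 2 and 4 differ only in the configuration as drawn

With that R configuration kept, phenethyl in place of phenyl on the chain gives a number at least 2 percentage points lower from compound 1 to compound 4 (that floor lies within the scatter), so no effect of the longer chain can be read in this configuration.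

Among the compounds shown here, still open is whether the S configuration at that carbon would also give a measurable read-out with the shorter benzyl substituent on the ring nitrogen or with 3-(hydroxycarbamoyl)phenyl on the aromatic carbon, since only one pair of compounds tests the stereocentre. Also open, from the compounds shown here alone, is what a primary amide or a methyl ester in place of the carboxylic acid, or a chain longer than phenylpropyl, would do in either configuration.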